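The compounds below may be only part of what the source reports. "The series", "measured", "known", "first", "only" and "open" are said of these compounds alone.

Measured compounds:
- compound 1, `O=C(Nn1c(-c2ccccc2)nc2c(-c3ccc(Cl)cc3)n[nH]c2c1=O)c1ccccc1`: in a functional assay on HT-29 cells (Homo sapiens) for inhibition, read by MTT assay, with a stated time of 2 days (a higher number here means a weaker inhibitor of growth, a lower number a stronger inhibitor of growth), compound 1 gives 20600 nM
- compound 2, `COc1cccc(Cc2nc3c(-c4ccc(Cl)cc4)n[nH]c3c(=O)n2NC(=O)c2ccccc2)c1`: in this assay compound 2 gives 22100 nM

Compound 1 has the lower of the two numbers, but its nearest neighbour is compound 2, and the step of a 1.1-fold higher number from compound 1 to compound 2 (0.03 log units; within the scatter) lies within the scatter, so the two compounds cannot be ranked against each other. That single measured step replaced phenyl with 3-methoxybenzyl on the same aromatic carbon of the shared core, and the growth-inhibition number barely moved.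

Compound 3, `O=C(Nn1c(CCC2CCCC2)nc2c(-c3ccc(Cl)cc3)n[nH]c2c1=O)c1ccccc1`, differs from compound 1 in one place: 2-cyclopentylethyl in place of phenyl on an aromatic carbon. For the measured compounds named here, the only step that bears on this change is the one from compound 1 to compound 2, since it alters the same position, and it was small. It is, however, an imperfect guide, as 2-cyclopentylethyl carries a five-membered non-aromatic ring rather than an aromatic one, so the uncertainty is wider than that step alone suggests. On this basis compound 3 is expected to show a step of a 1.2-fold higher number from compound 1 to compound 3 (0.08 log units; within the scatter), that is, no change beyond the scatter, with an estimated value of 25000 nM in this assay, within a range of 8000 nM to 80000 nM.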

Compound 3, concentration for 50% growth inhibition: 1800 nM
Compound 3: middle estimate off by 14-fold (1.14 log units), on the high side; measured number below the stated range.
By their numbers in this assay, from the lowest: compound 3; then compounds 1 and 2 (each within the scatter of the next).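

At the aromatic carbon between two ring nitrogen atoms, the group is not interchangeable: in this assay, 2-cyclopentylethyl in place of phenyl gives an 11-fold lower number from compound 1 to compound 3 (1.06 log units; beyond the scatter) and so a clearly stronger inhibitor of growth. The step from the 3-methoxybenzyl compound is of similar size, with cyclopentylmethyl in place of 3-methoxyphenyl on the saturated chain carbon giving a 12-fold lower number from compound 2 to compound 3 (1.09 log units; beyond the scatter) in this assay. A saturated carbon bound directly to the core is therefore not enough for the lower number, as compound 2 has one too, and the earlier pair gave no sign that this position could move the number at all.

Compound 3 differs from compound 2 in both the length of its chain and the ring at its end, so the two cannot be told apart here; a 2-phenylethyl group would keep the chain and restore an aromatic ring, while a cyclopentyl group on the core or a straight pentyl chain would test each part alone. Nothing available here explains why the 2-cyclopentylethyl group goes with the lower number.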